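Trading trifluoromethoxy for fluoro on an aromatic carbon

The compounds below may be only part of what the source reports. "The series", "measured", "known", "first", "only" and "open" are said of these compounds alone.

In an ADME assay on microsomes from liver (Rattus norvegicus) for metabolic stability (on this read-out lower numbers stand for a shorter-lived compound and higher numbers for a longer-lived compound), compound 1 (`O=C1COc2cc(Nc3cc4c(cn3)ncn4CC3CC3)ccc2N1`) gives 0.983 h and compound 2 (`CN1C(=O)COc2cc(Nc3cc4c(cc3OC(F)(F)F)ncn4CC3CC3)cnc21`) gives 0.55 h as its half-life, so these two numbers sit within the usual scatter of each other. Compound 3 (`CN1C(=O)COc2cc(Nc3cc4c(cc3F)ncn4CC3CC3)cnc21`) has fluoro in place of trifluoromethoxy on an aromatic carbon. Among the measured compounds shown here, no measured pair of compounds shows this kind of change, so in this assay the expected step (a 1.5-fold higher number from compound 2 to compound 3 (0.16 log units; within the scatter)) is small, leaning towards a longer half-life but staying within the scatter. For compound 3 the estimated half-life is 0.8 h (expected range 0.35 h to 1.8 h).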

Compound 3, half-life: 0.283 h
Estimate against measurement, compound 3: 2.8-fold (0.45 log units) above; measured number outside the range, below it.
By their numbers in this assay, from the lowest: compounds 3, 2 and 1 (each within the scatter of the next, the first and the last beyond it).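

Among the compounds shown here, the first pair that differs in this one place gives, in this assay, a 1.9-fold lower number from compound 2 to compound 3 (0.29 log units; within the scatter). Here, a group of five heavy atoms gives way to a single fluorine on the same aromatic carbon, and the half-life stays within the usual scatter, so this swap at this position shows no clear effect on the read-out. No measurement shown here offers an explanation for this result. On these data alone, whether a chloro group, a methoxy group or a plain hydrogen at this position would shift the half-life beyond the scatter stays open.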